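Thiazolyl to Methoxyphenyl: Expected Efficacy at the Dopamine Receptor

This account rests on a few compounds, and the source may have more. Where it says the series, first, only, none or still open, it means among the compounds named here.

Compound 1 `O=C(NCN1CCC(c2cccc[n+]2[O-])CC1)c1ccccc1`: 63%
Compound 2 `Cc1cccc(NC(=O)CN2CCC(c3nccs3)CC2)c1`: 62%

In a functional assay on HEK293 cells for agonist activity at D(4) dopamine receptor (Homo sapiens), read by FLIPR (on this read-out higher numbers stand for larger maximal responses and lower numbers for smaller maximal responses), compound 2 gives 62%, a number that sits within the usual scatter of compound 1 at 63%, so the two measured compounds cannot be told apart. Compound 3 `COc1ccccc1C1CCN(CC(=O)Nc2cccc(C)c2)CC1` differs from compound 2 in one place: 2-methoxyphenyl in place of 1,3-thiazol-2-yl on a saturated ring carbon. Among the compounds with values here, no measured pair shows this change, so there is no comparable step to lean on. The expected step of a number 2 percentage points lower from compound 2 to compound 3 (within the scatter) is small, with no direction favoured beyond the scatter. Compound 3 is therefore estimated at 60%, within a broad range from 30% to 90%.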

Compound 3, largest response reached (reported as efficacy), in percent of the reference or control that the assay uses: 43%
For compound 3 the middle estimate is 17 percentage points above the measured one; the measured number falls inside the stated range.
By their numbers in this assay, from the lowest: compound 3; then compounds 2 and 1 (each within the scatter of the next).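

On the saturated ring carbon of the six-membered ring, the choice of group matters: in this assay, 2-methoxyphenyl in place of 1,3-thiazol-2-yl gives a number 19 percentage points lower from compound 2 to compound 3 (beyond the scatter). This is the first one-place change among these compounds, and it shows that the maximal response depends on what sits at this carbon. Nothing available explains this drop. Still open, from the compounds shown here alone, is whether the drop belongs to the methoxy group or to the phenyl ring that carries it; a plain phenyl on the same carbon would separate the two.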